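Shortening the hydroxycarbamoyl chain: compound 1 to compound 4

The source may hold more compounds than are shown below. What is called first, only, known or untested is meant among the compounds shown, and "the series" means these compounds.

Measured in a functional assay on MV4-11 cells (Homo sapiens) for antiproliferative activity, read by CCK-8 assay, with a stated time of 72 h; a lower number here means a stronger inhibitor, a higher number a weaker inhibitor:
- compound 1 `Cn1cc(-c2ccccc2Oc2ccccc2)c2cc(C(=O)NCCCCCCC(=O)NO)[nH]c2c1=O` gives 180 nM
- compound 2 `CC(C)Oc1ccc(C(C)(C)O)cc1-c1cn(C)c(=O)c2[nH]c(C(=O)NCCCCCCC(=O)NO)cc12` gives 160 nM
- compound 3 `Cn1cc(-c2ccccc2Oc2ccccc2)c2cc(C(=O)NCCCC(=O)NO)[nH]c2c1=O` gives 380 nM

Compound 1 stands level with compound 2 within the scatter, and only its step to compound 3 goes beyond the scatter. Compound 4 `Cn1cc(-c2ccccc2Oc2ccccc2)c2cc(C(=O)NCCCCCC(=O)NO)[nH]c2c1=O` changes the chain of compound 1 (hydroxycarbamoyl in place of (hydroxycarbamoyl)methyl on a saturated chain carbon, five bonds along the chain from an amide-type nitrogen): hydroxycarbamoyl in place of (hydroxycarbamoyl)methyl on a saturated chain carbon, five bonds along the chain from an amide-type nitrogen. Among the compounds with values here, one measured step bears on this, a modest one that shortens the same chain further (a 2.1-fold higher number from compound 1 to compound 3 (0.32 log units; beyond the scatter)). Within the data shown here, compound 2 offers no step here. A smaller change towards a higher number is therefore expected, within the scatter (a 1.3-fold higher number from compound 1 to compound 4 (0.11 log units; within the scatter)). In this assay the estimate for compound 4 is 230 nM (expected range 130 nM to 400 nM).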

Compound 4, half-maximal inhibitory concentration: 610 nM
For compound 4 the middle estimate is 2.7-fold (0.42 log units) below the measured one; measured number above the stated range.
By their numbers in this assay, from the lowest: compounds 2 and 1 (each within the scatter of the next); then compounds 3 and 4 (each within the scatter of the next).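

A single shortening of the chain of compound 1 already gives a step beyond the scatter (a 3.4-fold higher number from compound 1 to compound 4 (0.53 log units; beyond the scatter)), so the loss at this position does not depend on the further shortening in compound 3. The two shorter chains cannot be separated (a 1.6-fold higher number from compound 3 to compound 4 (0.21 log units; within the scatter)), and compound 3 goes against any graded loss with each shortening. Nothing available explains this loss at the chain.

On these data alone, a longer chain than that of compound 1 remains open, as does a carboxylic acid in place of hydroxycarbamoyl. Also open, as far as these compounds go, is whether the shorter chains behave alike with the substituted aryl group of compound 2.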